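Swapping a 4-Bromophenyl for a 2-Methylphenyl on the Amine

This account rests on a few compounds, and the source may have more. Where it says the series, first, only, none or still open, it means among the compounds named here.

Compound 3 `Fc1cccc(-c2nc(Nc3ccc(Br)cc3)c3cc(F)ccc3n2)c1` carries a 4-bromophenyl on a nitrogen on an aromatic ring of the shared core. In a functional assay on HT29-AK cells (Homo sapiens) for cytotoxicity, read by MTT assay, with a stated time of 48 h (on this read-out lower numbers stand for stronger inhibition and higher numbers for weaker inhibition), compound 3 gives > 50000 nM, which is a limit of the assay rather than a number. Within the data shown here, two close relatives change only that ring. Compound 1 `COc1ccc(Nc2nc(-c3cccc(F)c3)nc3ccc(F)cc23)cc1` gives 42300 nM in this assay. Compound 2 `COc1ccccc1Nc1nc(-c2cccc(F)c2)nc2ccc(F)cc12` gives > 50000 nM in this assay, again a limit rather than a number.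

Compound 4 `Cc1ccccc1Nc1nc(-c2cccc(F)c2)nc2ccc(F)cc12` is the next step from compound 3: 2-methylphenyl in place of 4-bromophenyl on a nitrogen on an aromatic ring. The measured steps that bear on it are small or unreadable: an at least 1.1-fold higher number from compound 1 to compound 3 (0.07 log units; that floor lies within the scatter), and a step that the two limits leave unreadable from compound 2 to compound 3. Compound 2, whose 2-methoxyphenyl is the closest match to the entering 2-methylphenyl, sits at the limit of > 50000 nM in this assay, at which 2 of the 3 values shown sit.

No change beyond the scatter is therefore expected; in this assay compound 4 is expected to show a step that the limit leaves unreadable from compound 3 to compound 4. The estimate for compound 4 is 70000 nM, with a range from 30000 nM to 200000 nM, and most likely only a limit is reported.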

Compound 4, half-maximal inhibitory concentration: > 50000 nM
Compound 4: no number, only a limit (the forecaster's own chance of this, stated with the estimate: 75%); the middle value is on the limit's open side.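

Compound 4 carries a methyl on the ring, with neither the bromo of compound 3 nor the methoxy of compound 2, and it still gives only a limit in this assay. Among these compounds, three different rings on this nitrogen now end at the same ceiling: the limit of > 50000 nM in this assay, at which 3 of the 4 values shown sit. The one readable comparison is an at least 1.1-fold higher number from compound 1 to compound 4 (0.07 log units; that floor lies within the scatter), while the steps from compound 3 to compound 4 and from compound 2 to compound 4 cannot be read, as both ends of each are limits.

On these data alone, whether an amine or a carboxylic acid on this ring, in place of the methyl, would give a clear number in this assay remains open. As far as these compounds go, how far compound 2, compound 3 and compound 4 lie past their shared limit, and so how they rank against each other, also remains open.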